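Methyl for hydrogen on the chain carbon: a second test

A few compounds are considered here, and "the series" means these few. Any claim that something is new, unique, unknown or untested is made for them only; others in the source may bear on it.

Measured so far:
- compound 1, `CCC(C(=O)N1CCN(c2ccc(F)cc2)CC1)N1C(=O)CCC1=O`: 0%
- compound 2, `CC(C(=O)N1CCN(c2ccc(F)cc2)CC1)N1C(=O)CCC1=O`: 50%
- compound 3, `CC(C(=O)N1CCN(c2ccccc2C(F)(F)F)CC1)N1C(=O)CCC1=O`: 75%

In a functional assay on the whole organism (strain Swiss) with Mus musculus as the target, in the maximal electroshock model, with a stated time of 2 h, at a dose of 300 mg/kg by the intraperitoneal route (on this read-out lower numbers stand for a weaker effect and higher numbers for a stronger effect at the one dose given), compound 2 gives 50%, while compound 1 gives 0%. The step between them, a number 50 percentage points lower from compound 2 to compound 1 (beyond the scatter), comes from methyl in place of hydrogen on a saturated chain carbon, two bonds along the chain from an amide-type nitrogen in a ring and a carbonyl carbon. Compound 3 carries a different core; how its core differs from that of compound 2 is not broken down here, but in this assay compound 3 gives 75%, the highest of the three numbers. Compound 4, `CCC(C(=O)N1CCN(c2ccccc2C(F)(F)F)CC1)N1C(=O)CCC1=O`, is not yet measured. It differs from compound 3 by methyl in place of hydrogen on a saturated chain carbon, two bonds along the chain from an amide-type nitrogen in a ring and a carbonyl carbon, the same change that separates compound 2 from compound 1. Because that earlier step was a number 50 percentage points lower from compound 2 to compound 1 (beyond the scatter), a drop of similar size is expected here, a number 50 percentage points lower from compound 3 to compound 4 (beyond the scatter), though it rests on one pair only. Compound 4 is therefore estimated at 25%, between 0% and 60%.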

Compound 4, a percentage reported as activity, at one dose (the size of the read-out at that dose, not a potency): 0%
Estimate against measurement, compound 4: 25 percentage points above; the measured number falls inside the stated range.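

In this assay, methyl in place of hydrogen on the chain carbon again brought a large fall, with a number 75 percentage points lower from compound 3 to compound 4 (beyond the scatter). The direction of the change carried from one core to the other, but its size did not: the same change on two cores in this assay, a number 50 percentage points lower (beyond the scatter) from compound 2 to compound 1 and a number 75 percentage points lower (beyond the scatter) from compound 3 to compound 4, 25 percentage points apart, beyond the scatter of two such steps Both steps end at the same reading, with compound 1 at 0% and compound 4 at 0%, and two pairs at a single dose neither show how large the loss would be on a further core nor give a reason for it.

The compounds shown leave open how a longer chain, such as propyl, or a hydroxyl group would read on this chain carbon. They also leave open whether the same fall appears on a core carrying a nitrile in place of trifluoromethyl.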